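This account rests on a few compounds, and the source may have more. Where it says the series, first, only, none or still open, it means among the compounds named here.

All four compounds share one core and differ only in the group attached to a single aromatic carbon. Compound 1 `Cc1cc(-c2ccco2)c2ncc(CSCCc3ccccc3)n2c1` carries a furan-2-yl there, and in an ADME assay on HEL cells (Homo sapiens) for cytotoxicity, with a stated time of 3 days (on this read-out lower numbers stand for higher toxicity in this test and higher numbers for lower toxicity in this test), compound 1 gives 41 ug/mL. Compound 2 `Cc1cc(N2CCN(C)CC2)c2ncc(CSCCc3ccccc3)n2c1` has no number in this assay, its entry being "not determined" (no result reported). Compound 3 `Cc1cc(-n2cccc2)c2ncc(CSCCc3ccccc3)n2c1` carries a 1H-pyrrol-1-yl, and in this assay compound 3 gives 26 ug/mL. For the measured compounds named here, that is one of only two numbers, and the step of a 1.6-fold lower number from compound 1 to compound 3 (0.20 log units; within the scatter) shows the two to lie within the scatter of each other, so neither can be called more or less toxic than the other.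

Compound 4 `Cc1cc(-n2ccc3cccnc32)c2ncc(CSCCc3ccccc3)n2c1` has not yet been measured in this assay. It differs from compound 3 by a group of 9 heavy atoms (7 carbon, 2 nitrogen; one five-membered aromatic ring with 1 hetero atom, one six-membered aromatic ring with 1 hetero atom) in place of a group of 5 heavy atoms (4 carbon, 1 nitrogen; one five-membered aromatic ring with 1 hetero atom), on an aromatic carbon. Going by the values given here, the one measured step that bears on this place, from compound 1 to compound 3, swapped one five-membered aromatic ring for another and stayed within the scatter. Among the compounds with values here, the new change keeps the five-membered ring with one nitrogen and joins a six-membered aromatic ring with one nitrogen to it; no measured step covers such an addition. With nothing pointing either way, the expected step is a 1.2-fold lower number from compound 3 to compound 4 (0.07 log units; within the scatter), that is, none beyond the scatter. Compound 4 is therefore estimated at 22 ug/mL, with a range from 9 ug/mL to 55 ug/mL.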

Compound 4, half-maximal cytotoxic concentration: > 100 ug/mL
Compound 4 was reported as a limit (the forecaster's own chance of this, stated with the estimate: 10%); middle value at least 4.5-fold (0.65 log units) away from the limit.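

Until now, this aromatic carbon had shown no clear effect in this assay: the one swap with two numbers, a 1.6-fold lower number from compound 1 to compound 3 (0.20 log units; within the scatter), stayed within the scatter. The group that keeps the five-membered aromatic ring and joins to it a six-membered aromatic ring with one nitrogen changes that, giving an at least 3.8-fold higher number from compound 3 to compound 4 (0.58 log units; beyond the scatter) and an at least 2.4-fold higher number from compound 1 to compound 4 (0.38 log units; beyond the scatter), so the choice of group at this position can matter, and here the change goes towards lower toxicity in this test. The entry for compound 4 is a limit and not a number: the limit of > 100 ug/mL in this assay, at which 1 of the 4 values shown sits.

The compounds shown leave open whether the added ring itself or the nitrogen within it goes with the higher number, a question that a fused six-membered ring made only of carbon, or a plain phenyl on this carbon, could help to settle. They also leave open how far the true number of compound 4 lies from its limit, and whether a saturated amine such as morpholine at this position would behave like the aromatic groups.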